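The source may hold more compounds than are shown below. What is called first, only, known or untested is meant among the compounds shown, and "the series" means these compounds.

Measured so far in an ADME assay on Huh-7 cells (Homo sapiens) for cytotoxicity, with a stated time of 72 h; on this read-out lower numbers stand for higher toxicity in this test and higher numbers for lower toxicity in this test:
Compound 1, `CS(=O)(=O)Nc1ccc2c(c1)S(=O)(=O)N=C(C1=C(O)C3CCCCCCC3N(Cc3ccc(F)cc3)C1=O)N2`: > 33000 nM
Compound 2, `CS(=O)(=O)Nc1ccc2c(c1)S(=O)(=O)N=C(C1=C(O)C3CCCC3N(C3CCCCC3)C1=O)N2`: > 10000 nM

Neither result is a number. For compound 1 the result is a limit of the assay, > 33000 nM (the limit of > 33000 nM in this assay, at which 1 of the 2 values shown sits). For compound 2 the result is likewise a limit of the assay, > 10000 nM (the limit of > 10000 nM in this assay, at which 1 of the 2 values shown sits). Among the measured compounds shown here, compound 2 thus stands at a limit, and the one further value shown is a limit too, so no step between the two measured compounds can be given.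

Compound 3, `CCN1C(=O)C(C2=NS(=O)(=O)c3cc(NS(C)(=O)=O)ccc3N2)=C(O)C2CCCC21`, differs from compound 2 in one place: ethyl in place of cyclohexyl on an amide-type nitrogen in a ring. With only limits to rest on, the expected step in this assay is none beyond the usual scatter, and a limit rather than a number is the likely outcome once more. The step from compound 2 to compound 3 is expected to be a step that the limit leaves unreadable from compound 2 to compound 3. Compound 3 is therefore expected at 30000 nM, within 10000 nM to 100000 nM.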

Compound 3, half-maximal cytotoxic concentration: > 33000 nM
Compound 3 was reported as a limit; the forecaster's own chance of this, stated with the estimate: 80%; middle value at least 1.1-fold (0.04 log units) from the limit.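

Compound 2 and compound 3 both stand at limits of this assay rather than at numbers, so no step can be read for ethyl in place of cyclohexyl. The compounds shown leave open whether this swap changes the read-out at all.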